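The compounds below may be only part of what the source reports. "The series", "measured", "known", "first", "only" and "open" are said of these compounds alone.

Working notes on the series. Compound 1 `S=c1[nH]nc(-c2ccccc2Sc2ccccc2)o1` and compound 3 `Nc1nnc(-c2ccccc2Sc2ccccc2)o1` share one core; in a functional assay on the whole organism (strain NMRI) for inhibition, with Mus musculus as the target, in the formalin test, with a stated time of 30 min, at a dose of 30 umol/kg by the intraperitoneal route (on this read-out lower numbers stand for less inhibition and higher numbers for more inhibition at the one dose given (going by the name of the read-out)), compound 1 gives 71.3% and compound 3 gives 63.7%. The change between them is a group of 6 heavy atoms (2 carbon, 3 nitrogen, 1 oxygen; one five-membered aromatic ring with 3 hetero atoms) in place of a group of 6 heavy atoms (2 carbon, 2 nitrogen, 1 oxygen, 1 sulfur; one five-membered aromatic ring with 3 hetero atoms), on an aromatic carbon, and it makes the step of a number 7.6 percentage points lower from compound 1 to compound 3 (within the scatter). Compound 2 `[O-][S+](c1ccccc1)c1ccccc1-c1n[nH]c(=S)o1` differs from compound 1 in its core, and that difference is not broken down here. In this assay compound 2 gives 86.1%, the highest of the three numbers, its gap to each of the others lying beyond the scatter. Compound 4 `Nc1nnc(-c2ccccc2[S+]([O-])c2ccccc2)o1` is not yet measured and stands to compound 2 as compound 3 stands to compound 1: a group of 6 heavy atoms (2 carbon, 3 nitrogen, 1 oxygen; one five-membered aromatic ring with 3 hetero atoms) in place of a group of 6 heavy atoms (2 carbon, 2 nitrogen, 1 oxygen, 1 sulfur; one five-membered aromatic ring with 3 hetero atoms), on an aromatic carbon. The surroundings of the changed carbon differ between the two pairs, as the two descriptions of the change show, so this is the same kind of change, not the same. For compound 4 a step of a number 7.6 percentage points lower from compound 2 to compound 4 (within the scatter) in this assay is expected beside the earlier one. For the measured compounds named here, that expectation rests on the step of a number 7.6 percentage points lower from compound 1 to compound 3 (within the scatter) from the single measured pair. Compound 4 is expected to give about 78.5%, between 66% and 90%.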

Compound 4, a percentage reported as inhibition, in the whole organism at one dose (the size of the read-out at that dose, not a potency): 79.9%
Beside the measured number, compound 4's estimate is 1.4 percentage points below it; measured number inside the range.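

In this assay, putting 5-amino-1,3,4-oxadiazol-2-yl in place of the group that leaves gives a step of a number 6.2 percentage points lower from compound 2 to compound 4 (within the scatter), and the two steps match: the same change on two cores in this assay, a number 7.6 percentage points lower (within the scatter) from compound 1 to compound 3 and a number 6.2 percentage points lower (within the scatter) from compound 2 to compound 4, 1.4 percentage points apart, within the scatter of two such steps. The change therefore carries from the core of compound 1 to the core of compound 2 with no difference that can be read between the steps. This does not show that the change has a real effect, since each step alone lies within the scatter, and two cores at one dose say nothing about other cores or about potency.

From the compounds shown here alone, what a carboxylic acid or a simple amine on that aromatic carbon would give remains open. Going by these compounds, the size of this step at other doses also remains open.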